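Benzylsulfonyl ester in place of basic side chain

A few compounds are considered here, and "the series" means these few. Any claim that something is new, unique, unknown or untested is made for them only; others in the source may bear on it.

Measured so far:
compound 1 `COc1ccc(/C=C/C(=O)c2ccc(OC)c3c2OC(C)(C)C=C3)cc1OCCCN(C)C`: 2920 nM in a functional assay on K562 cells (Homo sapiens) for cytotoxicity, read by MTT assay; a higher number here means a weaker inhibitor, a lower number a stronger inhibitor
compound 2 `COc1cccc(C(=O)Oc2cc(/C=C/C(=O)c3ccc(OC)c4c3OC(C)(C)C=C4)ccc2OC)c1`: 790 nM in this assay

For the measured compounds named here, compound 1 stands highest of the two numbers in this assay; the one measured step in the set is a 3.7-fold lower number from compound 1 to compound 2 (0.57 log units; beyond the scatter), in which (3-methoxyphenyl)carbonyl replaces 3-(dimethylamino)propyl on an oxygen on an aromatic ring.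

Compound 3 `COc1ccc(/C=C/C(=O)c2ccc(OC)c3c2OC(C)(C)C=C3)cc1OS(=O)(=O)Cc1ccccc1` has not been measured in this assay. It differs from compound 1 as follows: benzylsulfonyl in place of 3-(dimethylamino)propyl on an oxygen on an aromatic ring. Going by the values given here, the change is of the same kind as the one measured step: the 3-(dimethylamino)propyl leaves the same aromatic oxygen and an aryl-bearing group that is an ester of that oxygen enters, so the step from compound 1 to compound 2 is the only bearing on it. That step was modest and beyond the scatter, towards a lower number. Among the compounds with values here, a step of comparable size and direction is therefore expected for compound 3, a 2.7-fold lower number from compound 1 to compound 3 (0.42 log units; beyond the scatter), though the entering group is larger than in compound 2 and the data give no second example of such an ester, so the range is kept wide. Compound 3 is estimated at 1100 nM, between 400 nM and 3000 nM.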

Compound 3, half-maximal inhibitory concentration: > 10000 nM
Compound 3 gave a limit, no number; the forecaster's own chance of this, stated with the estimate: 5%; middle value at least 9.0-fold (0.95 log units) from the limit.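

In this assay, the earlier step suggested that an ester on this aromatic oxygen could improve on the basic side chain of compound 1, but the sulfonyl ester reverses that direction: an at least 3.4-fold higher number from compound 1 to compound 3 (0.53 log units; beyond the scatter). Benzylsulfonyl in place of (3-methoxyphenyl)carbonyl on the same oxygen gives an at least 12-fold higher number from compound 2 to compound 3 (1.10 log units; beyond the scatter), so the outcome at this position depends on which ester group enters and not simply on the departure of the 3-(dimethylamino)propyl. The result for compound 3 is a limit and not a number, so both steps give only a minimum size: the limit of > 10000 nM in this assay, at which 1 of the 3 values shown sits.

From the compounds shown here alone, whether the drop follows the sulfonyl link or the benzyl part remains open, and a methylsulfonyl or phenylsulfonyl group on this oxygen, or a phenylacetyl ester carrying the same benzyl part through a carbonyl, would separate the two. Also open, going by these compounds, is how a free hydroxyl on this oxygen would compare with these groups, and whether a plain benzoyl ester without the methoxy group would hold the number of compound 2.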